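Aryl variation at the indane core: pyridin-3-yl replaces methylpyrazolyl

The source may hold more compounds than are shown below. What is called first, only, known or untested is meant among the compounds shown, and "the series" means these compounds.

Measured so far:
Compound 1 `c1ccc(-c2cccc3c2CCC3c2ncc[nH]2)nc1` gives in a functional assay on CHO cells for agonist activity at Alpha-1B adrenergic receptor (Homo sapiens), read by FLIPR and calcium flux (a higher number here means that more compound is needed for the effect, a lower number that less compound is needed), a limit, > 10000 nM.
Compound 2 `Cn1nccc1-c1cccc2c1CCC2c1ncc[nH]1` gives in this assay a limit, > 10000 nM.

Compound 2 stands at the limit of this assay; its value is not a number but the upper bound the assay reports. Among the compounds with values here, the only measured step, a step that the two limits leave unreadable from compound 1 to compound 2, cannot be read because the limit of > 10000 nM in this assay, at which 2 of the 2 values shown sit, holds both ends.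

Compound 3 `c1cncc(-c2cccc3c2CCC3c2ncc[nH]2)c1` is not yet measured. It differs from compound 2 by pyridin-3-yl in place of 1-methyl-1H-pyrazol-5-yl on an aromatic carbon. The step from compound 1 to compound 2 is the only one that bears on this aryl position, and its size is unreadable, so no direction and no magnitude can be taken from it. Two of two compounds sitting at the limit is the whole basis for expectation.

Compound 3 is therefore expected to sit at or near the limit again, with a step that the limit leaves unreadable from compound 2 to compound 3 that is no more than nominal. The estimate for compound 3 in this assay is 15000 nM, within 4000 nM to 60000 nM.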

Compound 3, half-maximal effective concentration: > 10000 nM
Compound 3 ended at the assay's limit (the forecaster's own chance of this, stated with the estimate: 80%); the middle value does not contradict the limit.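

No step among compound 1, compound 2 and compound 3 can be read in this assay, as all three values are limits and not numbers: the limit of > 10000 nM in this assay, at which 3 of the 3 values shown sit.

The compounds shown leave open how pyridin-2-yl, pyridin-3-yl and 1-methyl-1H-pyrazol-5-yl rank against one another, and whether any group on this aromatic carbon gives a numerical value in this assay.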